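One more methoxy on compound 1: what to expect

The source may report more compounds than this note shows. Statements on the series, on what has been measured and on what is new or still open speak of the compounds shown alone.

Values measured so far in a functional assay on 786-0 cells (Homo sapiens) for inhibition, read by sulforhodamine B assay, with a stated time of 48 h; a lower number here means a stronger inhibitor of growth, a higher number a weaker inhibitor of growth
- compound 1 `COc1ccc(/C=C/C2(C)C=CC(=O)O2)cc1OC` gives 22900 nM
- compound 2 `COc1ccc(/C=C/C2(C)C=CC(=O)O2)c(OC)c1OC` gives 132000 nM
- compound 3 `COc1cc(OC)c(OC)cc1/C=C/C1(C)C=CC(=O)O1` gives 205000 nM

Compound 1 has the lowest number of the three, and both of its steps to the others lie beyond the scatter, so it is the strongest growth inhibitor in this small set. Compound 4 `COc1cc(/C=C/C2(C)C=CC(=O)O2)cc(OC)c1OC` has not yet been measured. It differs from compound 1 by a single change methoxy in place of hydrogen on an aromatic carbon in which methoxy takes the place of hydrogen on an aromatic carbon.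

Two measured steps involve the same kind of swap, each at a different carbon. One is a 5.8-fold higher number from compound 1 to compound 2 (0.76 log units; beyond the scatter) and the other is a 9.0-fold higher number from compound 1 to compound 3 (0.95 log units; beyond the scatter) in this comparison. Both are modest, and both point toward weaker growth inhibition. Two steps are thin evidence, and neither is made at the carbon that changes in compound 4, so the expectation is uncertain. A modest step in the same direction is still the likeliest outcome in this assay for this change. The expected size is a 5.2-fold higher number from compound 1 to compound 4 (0.72 log units; beyond the scatter) by this estimate. For compound 4 the estimated value is 120000 nM with an expected range from 40000 nM to 260000 nM once it is measured.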

Compound 4, concentration for total growth inhibition: 116000 nM
For compound 4 the middle estimate is 1.0-fold (0.01 log units) above the measured one; measured number inside the range.
By their numbers in this assay, from the lowest: compound 1; then compounds 4, 2 and 3 (each within the scatter of the next).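

In this assay the new step is a 5.1-fold higher number from compound 1 to compound 4 (0.70 log units; beyond the scatter) and shows that a methoxy on this carbon, ortho to a methoxy group and meta to the group of 9 heavy atoms, also goes with weaker growth inhibition. The earlier compounds showed this for two other carbons only, through a 5.8-fold higher number from compound 1 to compound 2 (0.76 log units; beyond the scatter) and a 9.0-fold higher number from compound 1 to compound 3 (0.95 log units; beyond the scatter); there are now three carbons of the same ring where this swap gives a higher number beyond the scatter, and no compound shown goes against that. Nothing available here gives a reason for the rise at this carbon.

Methoxy is the only group shown entering at any of these three carbons, so it remains open whether a hydroxyl group, a fluorine atom or an amine on this same carbon would also give a number higher than that of compound 1. As far as these compounds go, it is equally open whether a longer chain on the oxygen, such as ethoxy in place of methoxy, would move the number further or bring it back toward compound 1.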